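The source may report more compounds than this note shows. Statements on the series, on what has been measured and on what is new or still open speak of the compounds shown alone.

Measured compounds:
- compound 1 `Cc1cccc(NC(=O)CN2CCC(c3ccc(Cl)cc3)CC2)c1`: "not active" (no number reported)
- compound 2 `O=C(CN1CCN(c2ccccn2)CC1)Nc1cccnc1`: 47.3%
- compound 3 `CCc1cccc(NC(=O)CN2CCN(c3ccc(Cl)cn3)CC2)c1`: "not active" (no number reported)

Compound 1 stands without a number in a functional assay on cells for agonist activity at D(4) dopamine receptor (Homo sapiens), read by TR-FRET and cAMP accumulation, with a stated time of 30 min; a lower number here means a smaller maximal response, a higher number a larger maximal response; compound 3 also carries no number there, and only compound 2 gives a figure in this assay. Compound 4 `Cc1cccc(NC(=O)CN2CCC(c3ccccc3)CC2)c1` is the next entry and is not yet measured. It differs from compound 1 by hydrogen in place of chloro on an aromatic carbon. Going by the values given here, no step between two measured compounds has been worked out for this change, so nothing known here anchors its size. Given that compound 1 returned no number in this assay, the expectation is that this change produces no step beyond the usual scatter, with compound 4 most likely reported in the same way. Should a number be reported, compound 4 is estimated at 10%, in a range from 0% to 30%.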

Compound 4, largest response reached (Emax), in percent of the reference or control that the assay uses: 32.9%
Estimate against measurement, compound 4: 22.9 percentage points below; the measured number lies above the stated range.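

In this assay, going by these compounds alone, compound 1 gives "not active" (no number reported) and compound 4 gives 32.9% with no step readable between the two. The compounds shown leave open the size of the change from 4-chlorophenyl to phenyl in a pair where both carry a number. No measured evidence bears on this result.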